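A few compounds are considered here, and "the series" means these few. Any claim that something is new, unique, unknown or untested is made for them only; others in the source may bear on it.

Compound 1 `Nc1cc(N)c2nc(-c3ccccc3)c(NCc3ccc(Cl)c(Cl)c3)nc2c1` gives 30900 nM in a functional assay on UACC-62 cells (Homo sapiens) for inhibition, read by sulforhodamine B assay, with a stated time of 48 h; on this read-out lower numbers stand for stronger inhibition of growth and higher numbers for weaker inhibition of growth. Compound 2 `Nc1cc(N)c2nc(-c3ccccc3)c(Sc3ccc(F)cc3)nc2c1` gives 31600 nM. Compound 3 `CCOC(=O)[C@H](CCC(=O)O)NC(=O)c1ccc(Oc2nc3cc(N)cc(N)c3nc2-c2ccccc2)cc1` gives 30900 nM.

On the numbers shown, compound 2 stands with the other two: its value differs from that of compound 1 and from that of compound 3 by gaps that lie within the usual scatter of repeated measurements, so the three compounds read as a single level of weak growth inhibition and none of them can be set apart from the others. Within the data shown here, no two of the measured compounds differ in only one place, so there is no measured step that shows what one small change does to this read-out.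

Compound 4 `COc1ccc(Sc2nc3cc(N)cc(N)c3nc2-c2ccccc2)cc1` has not yet been measured. It differs from compound 2 by methoxy in place of fluoro on an aromatic carbon. Among the measured compounds shown here, since every compound measured so far sits at the same level, the step of a 1.0-fold lower number from compound 2 to compound 4 (0.01 log units; within the scatter) in this assay is expected to be small and to stay within the scatter, with no clear direction. Compound 4 is therefore estimated to give about 31000 nM, within a range from 15000 nM to 65000 nM.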

Compound 4, concentration for total growth inhibition: < 100000 nM
Compound 4: only a limit was reported (the forecaster's own chance of this, stated with the estimate: 20%); the middle value lies beyond the limit too.
By their numbers in this assay, from the lowest: compounds 1, 3 and 2 (each within the scatter of the next).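

In this assay compound 4 gives < 100000 nM, which is a limit of the assay and not a number. Among these compounds, the change from compound 2 to compound 4, methoxy in place of fluoro, therefore gives no step that can be read. The compounds shown leave open whether this swap alters growth inhibition at all, and in which direction.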